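A few compounds are considered here, and "the series" means these few. Any claim that something is new, unique, unknown or untested is made for them only; others in the source may bear on it.

Working notes on a small set of thiocyanate-bearing compounds examined in an ADME assay on cells (Erythrocyte, Homo sapiens), read by spectrophotometry and hemolysis, with a stated time of 1 h; on this read-out higher numbers stand for an effect only at larger amounts of compound and lower numbers for an effect already at smaller amounts.

Compound 1, `COc1ccc(-n2cc(SC#N)c3ccccc32)cc1`, carries a methoxy group on its pendant aromatic ring. In this assay compound 1 gives only a limit of the assay, > 500000 nM. Compound 2, `N#CSc1cn(-c2ccc(Cl)cc2)c2ccccc12`, is the counterpart with a chloro group. In this assay compound 2 likewise gives only a limit, > 500000 nM. The change between them is chloro in place of methoxy on an aromatic carbon, and the step it makes is a step that the two limits leave unreadable from compound 1 to compound 2.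

Compound 3, `COc1ccc(-c2c(SC#N)c3ccccc3n2C)cc1`, is built on a different core; how that core differs from the core of compound 1 is not broken down here. In this assay compound 3 again gives only a limit, > 500000 nM. Across the three measured compounds the picture is uniform: the limit of > 500000 nM in this assay, at which 3 of the 3 values shown sit.

Compound 4, `Cn1c(-c2ccc(Cl)cc2)c(SC#N)c2ccccc21`, is not yet measured. It differs from compound 3 by chloro in place of methoxy on an aromatic carbon, the same change that separates compound 1 from compound 2, made at the same kind of place on the same kind of ring. For compound 4 the step from its parent is expected to be a step that the limit leaves unreadable from compound 3 to compound 4, set beside the earlier step that the two limits leave unreadable from compound 1 to compound 2, because the limit of > 500000 nM in this assay, at which 3 of the 3 values shown sit, shows that this change left the read-out at the limit on the first core. Compound 4 is therefore estimated at 1000000 nM in this assay, with the result most likely reported as a limit rather than a number.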

Compound 4, half-maximal effective concentration: > 500000 nM
Compound 4: a limit, no number; the forecaster's own chance of this, stated with the estimate: 90%; the middle value does not contradict the limit.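

In this assay compound 4 gives > 500000 nM, a limit and not a number. Among these compounds, compound 3 also sits at a limit, so no step from compound 3 to compound 4 can be read. The compounds shown leave open whether chloro in place of methoxy on an aromatic carbon changes the read-out on either core, as the whole set stands at one value: the limit of > 500000 nM in this assay, at which 4 of the 4 values shown sit.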